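Pyridyl Amide to Dihydroisoxazole Amide on a Catechol Ether

The source may report more compounds than this note shows. Statements on the series, on what has been measured and on what is new or still open speak of the compounds shown alone.

Compound 1 `O=C(Nc1c(F)cccc1F)c1cccc(OC2CCCC2)c1` gives 15000 nM in an assay on isolated protein for inhibition of phosphodiesterase 4A (Sus scrofa); on this read-out higher numbers stand for weaker inhibition and lower numbers for stronger inhibition.
Compound 2 `COc1ccc(C(=O)Oc2c(Cl)cccc2Cl)cc1OC1CCCC1` gives > 1000000 nM in this assay, which is a limit of the assay and not a number.
Compound 3 `COc1ccc(C(=O)Nc2ccccn2)cc1OC1CCCC1` gives 1000 nM in this assay.

Going by the values given here, of the two numbers known, compound 3 holds the lower one; compound 1 sits at a higher number, and the gap lies beyond the scatter. The reading of compound 2 is a limit only, and it is the limit described by the limit of > 1000000 nM in this assay, at which 1 of the 3 values shown sits.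

Compound 4 `COc1ccc(C(=O)NC2(C)C=C(C)ON2)cc1OC1CCCC1` is the next compound to be measured. It differs from compound 3 in one place: a group of 7 heavy atoms (5 carbon, 1 nitrogen, 1 oxygen; one five-membered non-aromatic ring with 2 hetero atoms) in place of a group of 6 heavy atoms (5 carbon, 1 nitrogen; one six-membered aromatic ring with 1 hetero atom), on an amide-type nitrogen. The pyridin-2-yl group is thus replaced by a five-membered non-aromatic ring with two hetero atoms and a further hydrogen-bond donor, on the amide-type nitrogen.

No measured step among these compounds resembles this exchange, so the expectation rests on the structural change alone. Compound 4 is expected to bind more weakly than compound 3, with a step of a 5.0-fold higher number from compound 3 to compound 4 (0.70 log units; beyond the scatter) estimated to lie beyond the scatter. The estimate for compound 4 is 5000 nM, with a range from 1000 nM to 30000 nM.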

Compound 4, half-maximal inhibitory concentration: 450 nM
For compound 4 the middle estimate is 11-fold (1.05 log units) above the measured one; measured number below the stated range.
By their numbers in this assay, from the lowest: compound 4; then compound 3; then compound 1. At a limit, above all of these: compound 2.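

On the amide-type nitrogen of this core, an aromatic ring is not needed to reach the number held by compound 3: in this assay, replacing pyridin-2-yl with the five-membered non-aromatic ring with two hetero atoms gives a 2.2-fold lower number from compound 3 to compound 4 (0.35 log units; beyond the scatter) and thus a modest gain rather than a loss. The position therefore accepts a non-aromatic ring that also carries a hydrogen-bond donor, which pyridin-2-yl lacks. Nothing shown explains the step or separates the contributions of the ring and the donor.

The compounds shown leave open whether a saturated ring without a hydrogen-bond donor, such as tetrahydropyran-4-yl, would keep this gain on the same nitrogen. They also leave open how a piperidin-4-yl group or a carboxylic acid carried on the entering ring would change the number.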